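The source may report more compounds than this note shows. Statements on the series, on what has been measured and on what is new or still open speak of the compounds shown alone.

Working notes on the amide series. The three measured compounds share one core and differ only in the group on the carbonyl carbon. In a functional assay on B16-F10 cells (Mus musculus) for inhibition, read by MTT assay, with a stated time of 48 h (a higher number here means a weaker inhibitor, a lower number a stronger inhibitor), compound 1 `COc1ccc(/C=C/c2cc(OC)cc(OC)c2/C=C/C(=O)NC2CC2)cc1` gives 10200 nM, compound 2 `COc1ccc(/C=C/c2cc(OC)cc(OC)c2/C=C/C(=O)N2CCCC2)cc1` gives 9280 nM, and compound 3 `CCCCNC(=O)/C=C/c1c(/C=C/c2ccc(OC)cc2)cc(OC)cc1OC` gives 2080 nM. Compound 3 therefore stands lowest of the three numbers: the nearest is compound 2 with a 4.5-fold lower number from compound 2 to compound 3 (0.65 log units; beyond the scatter) and the furthest is compound 1 with a 4.9-fold lower number from compound 1 to compound 3 (0.69 log units; beyond the scatter), both beyond the scatter. By contrast a 1.1-fold lower number from compound 1 to compound 2 (0.04 log units; within the scatter) lies within the scatter, so the secondary and tertiary amides of small size read the same.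

Compound 4 `CCCCCN(CCCCC)C(=O)/C=C/c1c(/C=C/c2ccc(OC)cc2)cc(OC)cc1OC` is not yet measured. It differs from compound 3 in one place: dipentylamino in place of butylamino on a carbonyl carbon. Among the measured compounds shown here, the steps that bear on it are a 4.9-fold lower number from compound 1 to compound 3 (0.69 log units; beyond the scatter) and a 4.5-fold lower number from compound 2 to compound 3 (0.65 log units; beyond the scatter), both modest and both ending at the butylamino group of compound 3. For the measured compounds named here, no measured step covers a change from butylamino to a larger tertiary amide; the only secondary-to-tertiary comparison available is flat. The expectation is therefore a step of roughly a 1.9-fold higher number from compound 3 to compound 4 (0.28 log units; within the scatter), leaning toward a higher number but not confidently beyond the scatter. Compound 4 is estimated at 4000 nM, with a range from 1200 nM to 14000 nM.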

Compound 4, half-maximal inhibitory concentration: 9270 nM
The estimate for compound 4 lay 2.3-fold (0.37 log units) below the measured number, within the range that was stated.
By their numbers in this assay, from the lowest: compound 3; then compounds 4, 2 and 1 (each within the scatter of the next).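

In this assay, the lower number of compound 3 does not carry over to the dipentylamino group on the carbonyl carbon (a 4.5-fold higher number from compound 3 to compound 4 (0.65 log units; beyond the scatter)), so this position does not simply tolerate any group with alkyl chains. Compound 4 instead reads level with the two compounds carrying much shorter groups, pyrrolidin-1-yl (a 1.0-fold lower number from compound 2 to compound 4 (0.00 log units; within the scatter)) and cyclopropylamino (a 1.1-fold lower number from compound 1 to compound 4 (0.04 log units; within the scatter)), which leaves butylamino alone in standing apart among these four compounds, while going from butylamino to dipentylamino, which has more heavy atoms, removes that difference entirely. Nothing in the data shown speaks to why the number moves at this position.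

The step from compound 3 to compound 4 changes the chain length and removes the amide hydrogen together, and compound 1 keeps that hydrogen without matching compound 3, so the two changes remain unseparated. A pentylamino or hexylamino group would test chain length with the amide hydrogen kept, and a dibutylamino group would test the loss of that hydrogen with chains of the same length as in compound 3.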